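Thiophene-fused amines: moving from aryl to benzyl substituent

The source may report more compounds than this note shows. Statements on the series, on what has been measured and on what is new or still open speak of the compounds shown alone.

Compound 1, `CNc1nc(/C=C/c2cc(OC)c(OC)c(OC)c2)nc2ccsc12`, in a functional assay on L02 cells (Homo sapiens) for inhibition, read by Griess assay, with stated times of 1 h and 24 h (a higher number here means a weaker inhibitor, a lower number a stronger inhibitor), gives > 1000000 nM, which is a limit of the assay.
Compound 2, `COc1cc(/C=C/c2nc(N(C)C)c3sccc3n2)cc(OC)c1OC`, in this assay gives > 1000000 nM, also a limit.
Compound 3, `COc1cc(/C=C/c2nc(Nc3ccc(C(F)(F)F)cc3)c3sccc3n2)cc(OC)c1OC`, in this assay gives 436000 nM.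

Compound 3 therefore holds the only number shown; the other two values are limits. Compound 4 is `COc1cc(/C=C/c2nc(NCc3ccc(C)cc3)c3sccc3n2)cc(OC)c1OC`, not yet measured. It differs from compound 3 in one place: 4-methylbenzyl in place of 4-(trifluoromethyl)phenyl on a nitrogen on an aromatic ring. The measured steps that touch this position are an at least 2.2-fold lower number from compound 1 to compound 3 (0.36 log units; beyond the scatter) and an at least 2.2-fold lower number from compound 2 to compound 3 (0.36 log units; beyond the scatter), both of which replaced a small alkyl group on the same nitrogen with the trifluoromethyl-bearing aryl group; the step that the two limits leave unreadable from compound 1 to compound 2 stays unreadable because of the limit of > 1000000 nM in this assay, at which 2 of the 3 values shown sit. Compound 4 keeps an aromatic ring on that nitrogen but inserts a methylene and exchanges trifluoromethyl for methyl, so the expectation is a step close to or within the scatter, a 1.1-fold higher number from compound 3 to compound 4 (0.06 log units; within the scatter), with a real chance that only a limit is reported. Compound 4 is estimated at 500000 nM, between 150000 nM and 1500000 nM.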

Compound 4, half-maximal inhibitory concentration: > 1000000 nM
Compound 4: only a limit was reported; the forecaster's own chance of this, stated with the estimate: 40%; at least 2.0-fold (0.30 log units) between middle value and limit.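

Exchanging 4-(trifluoromethyl)phenyl for 4-methylbenzyl on this nitrogen gives, in this assay, an at least 2.2-fold higher number from compound 3 to compound 4 (0.36 log units; beyond the scatter). Compound 4 thus shows that a six-membered aromatic ring on this nitrogen is not enough by itself to give a readable number, and among the compounds shown only compound 3 gives one. The steps from compound 1 and from compound 2 to compound 4 cannot be read, because both ends of each are limits: the limit of > 1000000 nM in this assay, at which 3 of the 4 values shown sit.

This exchange alters both the link to the ring and the group the ring carries, so the compounds shown do not tell which of the two matters. The same nitrogen bearing 4-methylphenyl or 4-(trifluoromethyl)benzyl would separate them.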